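This account rests on a few compounds, and the source may have more. Where it says the series, first, only, none or still open, it means among the compounds named here.

Measured compounds and values in a physicochemical assay for lipophilicity, in phosphate buffer, measured as octanol-water partition; on this read-out higher numbers stand for higher lipophilicity and lower numbers for lower lipophilicity:
- compound 1 `CCCc1nc2ccccc2c(=O)n1/N=C/c1ccc(Oc2ccc(F)cc2)cc1`: 5.22
- compound 2 `O=c1c2ccccc2nc(-c2ccccc2)n1/N=C/c1ccc(Oc2ccc([N+](=O)[O-])cc2)cc1`: 6.12
- compound 3 `Cc1cc(Oc2ccc(/C=N/n3c(-c4ccccc4)nc4ccccc4c3=O)cc2)ccc1Cl`: 6.52

Compound 3 gives the highest of the three numbers; compound 2 lies nearest to it and compound 1 furthest. The step from compound 3 to compound 4 `O=c1c2ccccc2nc(-c2ccccc2)n1/N=C/c1ccc(Oc2ccc(F)cc2)cc1` is 4-fluorophenyl in place of 4-chloro-3-methylphenyl on an oxygen on an aromatic ring. Among the measured compounds shown here, the only measured step at this position is a number 0.40 log units higher from compound 2 to compound 3 (beyond the scatter), a modest one. Compound 1, which also carries the 4-fluorophenoxy group but differs in the core, gives a lower number than compounds 2 and 3, so a decrease beyond the scatter is expected on this assay for compound 4, estimated as a number 0.62 log units lower from compound 3 to compound 4 (beyond the scatter). Compound 4 is expected to give 5.9, with a range from 5.3 to 6.5.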

Compound 4, partition coefficient: 6.21
For compound 4 the middle estimate is 0.31 log units below the measured one, within the range that was stated.
By their numbers in this assay, from the lowest: compound 1; then compounds 2 and 4 (each within the scatter of the next); then compound 3.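

In this assay the change to 4-fluorophenyl on the oxygen gives a step in the downward direction (a number 0.31 log units lower from compound 3 to compound 4 (beyond the scatter)), while fluoro in place of nitro on the same ring leaves the two compounds indistinguishable (a number 0.09 log units higher from compound 2 to compound 4 (within the scatter)). With the 4-fluorophenoxy group held fixed, phenyl in place of propyl on an aromatic carbon gives the largest of the new steps (a number 0.99 log units higher from compound 1 to compound 4 (beyond the scatter)). Nothing available explains the size of these steps.

Still open, on these data alone, is whether an amine or a carboxylic acid in place of 4-fluorophenyl on the oxygen would fit these steps. As far as these compounds go, a longer chain in place of propyl is equally open.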